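The compounds below may be only part of what the source reports. "The series", "measured", "known", "first", "only" and "open" are said of these compounds alone.

In a functional assay on HGC-27 cells (Homo sapiens) for inhibition, read by MTT assay, with a stated time of 72 h (a higher number here means a weaker inhibitor, a lower number a stronger inhibitor), two compounds have been measured:

- Compound 1 `Cc1cc(N2CC[C@@H](C)[C@@H](N(C)c3ncnc4[nH]ccc34)C2)n2nc(SCc3ccc(Cl)cc3)nc2n1`: 18400 nM
- Compound 2 `Cc1cc(N2CC[C@@H](C)[C@@H](N(C)c3ncnc4[nH]ccc34)C2)n2nc(SCc3csc4ccc(Cl)cc34)nc2n1`: > 100000 nM

The value of compound 2 is a limit of the assay and not a number, and it stands at the limit of > 100000 nM in this assay, at which 1 of the 2 values shown sits. Compound 3 `Cc1cc(N2CC[C@@H](C)[C@@H](N(C)c3ncnc4[nH]ccc34)C2)n2nc(SCc3ccc(F)c(Cl)c3)nc2n1` carries 3-chloro-4-fluorophenyl in place of 5-chloro-1-benzothiophen-3-yl on a saturated chain carbon bound to a sulfur. Among the compounds with values here, one measured step bears on this change: an at least 5.4-fold higher number from compound 1 to compound 2 (0.73 log units; beyond the scatter), beyond the scatter, which brought in the same 5-chloro-1-benzothiophen-3-yl in place of 4-chlorophenyl. Compound 3 again has a single six-membered aromatic ring there, so a return towards compound 1 at 18400 nM is expected in this assay, with a step of similar size towards a lower number. The estimate is an at least 4.0-fold lower number from compound 2 to compound 3 (0.60 log units; beyond the scatter). For compound 3 the expected value is 25000 nM, with an estimated range of 8000 nM to 80000 nM.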

Compound 3, half-maximal inhibitory concentration: > 100000 nM
Compound 3 gave a limit, no number; the forecaster's own chance of this, stated with the estimate: 20%; middle value at least 4.0-fold (0.60 log units) away from the limit.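

In this assay, going back to a single six-membered aromatic ring did not recover a measurable value, so the loss is not confined to the two-ring 5-chloro-1-benzothiophen-3-yl group: 3-chloro-4-fluorophenyl in place of 4-chlorophenyl gives an at least 5.4-fold higher number from compound 1 to compound 3 (0.73 log units; beyond the scatter). Of the three groups on the saturated chain carbon bound to a sulfur, only the 4-chlorophenyl of compound 1 gives a number, 18400 nM. The step between compound 2 and compound 3 cannot be read, because both values are limits of the assay and not numbers: the limit of > 100000 nM in this assay, at which 2 of the 3 values shown sit.

Going by these compounds, it remains open whether the fluorine or the placement of the chlorine in compound 3 accounts for this step. Also open, on these data alone, is whether a plain phenyl, or a phenyl carrying an amine or a carboxylic acid, would give a number at this position.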